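The compounds below may be only part of what the source reports. "The series", "measured", "known", "first", "only" and "open" are said of these compounds alone.

Measured compounds:
Compound 1, `COc1ccc2nc(COc3ccc(CC(SSCC(N)C(=O)O)C(=O)O)cc3)n(C)c2c1`: 12.3 ng.h/mL
Compound 2, `COc1ccc2nc(COc3ccc(CC(C(N)=O)S(C)(=O)=O)cc3)n(C)c2c1`: 27 ng.h/mL

In an ADME assay on the whole organism (plasma) for pharmacokinetics, with Rhesus monkey (Macaca mulatta) as the target, read by LC-MS, at a dose of 1 mg/kg by the oral route (a lower number here means less compound in the circulation, a higher number more compound in the circulation at the dose given), compound 2 gives 27 ng.h/mL, the higher of the two numbers in hand. Compound 1 gives 12.3 ng.h/mL in this assay, a gap that lies beyond the usual scatter, so compound 2 reaches the circulation to a greater extent than compound 1 on these two readings.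

Compound 3, `COc1ccc2nc(COc3ccc(CC(SC)C(=O)O)cc3)n(C)c2c1`, has not yet been measured. It differs from compound 2 in one place: carboxy(methylsulfanyl)methyl in place of carbamoyl(methylsulfonyl)methyl on a saturated chain carbon bound to an aromatic carbon. Within the data shown here, no step between measured compounds covers this change, so the direction has to be guessed from the two values alone. Compound 1, which also carries a carboxy group on that chain carbon, sits lower than compound 2, which leans the expectation toward no gain. For compound 3 the expected step is a 1.4-fold lower number from compound 2 to compound 3 (0.13 log units; within the scatter), a modest fall or none beyond the scatter. Compound 3 is therefore estimated at 20 ng.h/mL, within a range from 5 ng.h/mL to 80 ng.h/mL.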

Compound 3, area under the concentration-time curve: 76.8 ng.h/mL
Compound 3: middle estimate off by 3.8-fold (0.58 log units), on the low side; low and high end bracket the measured number.
By their numbers in this assay, from the lowest: compound 1; then compound 2; then compound 3.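

In this assay, carboxy(methylsulfanyl)methyl in place of carbamoyl(methylsulfonyl)methyl on a saturated chain carbon bound to an aromatic carbon gives a 2.8-fold higher number from compound 2 to compound 3 (0.45 log units; beyond the scatter), so this position can move the number upward, and a carboxy group there does not by itself hold it low. With the carboxy group kept, methyl in place of (2-amino-2-carboxyethyl)sulfanyl on a sulfur gives a 6.2-fold higher number from compound 1 to compound 3 (0.80 log units; beyond the scatter), which shows that the group on the sulfur also matters. No measurement at hand offers a reason for either step.

The step from compound 2 bundles two differences, and the compounds shown do not tell whether the carboxylic acid or the thioether carries it. Going by these compounds, an ethyl on the sulfur, or a carboxylic acid paired with methylsulfonyl, remains untested in these compounds.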